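A few compounds are considered here, and "the series" means these few. Any claim that something is new, unique, unknown or untested is made for them only; others in the source may bear on it.

Measured compounds:
Compound 1 `COc1ccc(-c2nc(CNc3ccc(C(=O)NO)cc3)n(-c3ccccc3)n2)cc1` — 163 nM
Compound 2 `O=C(NO)c1ccc(NCc2nc(-c3ccc(F)cc3)nn2-c2ccccc2)cc1` — 115 nM
Compound 3 `Cc1cccc(-c2nc(CNc3ccc(C(=O)NO)cc3)n(-c3ccccc3)n2)c1` — 281 nM

Three compounds share one core and differ only in the aryl group attached to the five-membered ring. In an assay on Sf9 cells for inhibition of protein deacetylase HDAC6 (Homo sapiens), read by fluorescence, with a stated time of 40 min (on this read-out higher numbers stand for weaker inhibition and lower numbers for stronger inhibition), compound 3 gives 281 nM, the highest of the three numbers. Its distance from compound 1 is small, a 1.7-fold higher number from compound 1 to compound 3 (0.24 log units; within the scatter), while its distance from compound 2 is larger, a 2.4-fold higher number from compound 2 to compound 3 (0.39 log units; beyond the scatter). The exchange of the methoxy group for fluorine, a 1.4-fold lower number from compound 1 to compound 2 (0.15 log units; within the scatter), also stays within the scatter.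

Compound 4 `O=C(NO)c1ccc(NCc2nc(-c3ccccc3Cl)nn2-c2ccccc2)cc1` is the next member of this series and has not yet been measured. It differs from compound 3 in one place: 2-chlorophenyl in place of 3-methylphenyl on an aromatic carbon. The two measured steps that swap this aryl group, a 1.7-fold higher number from compound 1 to compound 3 (0.24 log units; within the scatter) and a 2.4-fold higher number from compound 2 to compound 3 (0.39 log units; beyond the scatter), bear directly on the question, and both were small. On that basis only a small step in this assay is expected for compound 4, most likely toward a lower number, and quite possibly none beyond the scatter. Compound 4 is therefore estimated to give 200 nM, within a range from 90 nM to 450 nM. The expected step is a 1.4-fold lower number from compound 3 to compound 4 (0.15 log units; within the scatter).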

Compound 4, half-maximal inhibitory concentration: 185 nM
Beside the measured number, compound 4's estimate is 1.1-fold (0.03 log units) above it, within the range that was stated.
By their numbers in this assay, from the lowest: compounds 2, 1, 4 and 3 (each within the scatter of the next, the first and the last beyond it).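

In this assay, 2-chlorophenyl, the only one of the four aryl groups that carries chlorine, gives a number within the scatter of all three earlier compounds: a 1.5-fold lower number from compound 3 to compound 4 (0.18 log units; within the scatter), a 1.6-fold higher number from compound 2 to compound 4 (0.21 log units; within the scatter) and a 1.1-fold higher number from compound 1 to compound 4 (0.05 log units; within the scatter). Compound 4 therefore adds no new gap beyond the scatter, and the only such gap among the four compounds remains a 2.4-fold higher number from compound 2 to compound 3 (0.39 log units; beyond the scatter), so this position accepts 4-methoxyphenyl, 4-fluorophenyl, 3-methylphenyl and 2-chlorophenyl with only a modest spread in the numbers. Nothing available here explains why these four aryl groups give such closely spaced numbers.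

From the compounds shown here alone, all four compounds carry a phenyl ring with a single substituent at this position, so it remains open whether an amine or a carboxylic acid on that ring, or a longer chain in place of the ring, would stay within the same narrow band. The phenyl group on the ring nitrogen is also the same throughout, which leaves open what a pyridine or a cyclohexyl group would do there.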